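The compounds below may be only part of what the source reports. "The series", "measured", "known", "first", "only" and "open" are said of these compounds alone.

Of the compounds shown here, three built on one shared core have been tested in a functional assay (ileum) for inhibition, with Cavia porcellus as the target; on this read-out lower numbers stand for an effect already at smaller amounts and higher numbers for an effect only at larger amounts of compound. Compound 1 `CC(C)NC1=NS(=O)(=O)c2cccnc2N1` gives > 300 uM in this assay, which is a limit of the assay rather than a number. Compound 2 `C[C@@H](NC1=NS(=O)(=O)c2cccnc2N1)C1CCCCC1` differs from compound 1 in more than one place, and the difference between the two cores is not broken down here. In this assay compound 2 gives > 300 uM, again only a limit. Compound 3 `CC(C)NC1=NS(=O)(=O)c2cc(Cl)cnc2N1` arises from compound 1 by one change, (chloro in place of hydrogen on an aromatic carbon). In this assay compound 3 gives > 300 uM, also a limit. The step that the two limits leave unreadable from compound 1 to compound 3 therefore cannot be sized, because of the limit of > 300 uM in this assay, at which 3 of the 3 values shown sit. Compound 4 `C[C@@H](NC1=NS(=O)(=O)c2cc(Cl)cnc2N1)C1CCCCC1` arises from compound 2 by the same change, (chloro in place of hydrogen on an aromatic carbon). Resting on compound 2 with > 300 uM and on the unreadable step from compound 1 to compound 3, the step from compound 2 to compound 4 is expected to be a step that the limit leaves unreadable from compound 2 to compound 4. Compound 4 is thus expected to give about 400 uM in this assay, most likely again reported as a limit, somewhere between 100 uM and 1500 uM.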

Compound 4, concentration for half-maximal effect: 13.6 uM
Compound 4: middle estimate off by 29-fold (1.47 log units), on the high side, and the stated range ends above it.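

In this assay, chloro in place of hydrogen on an aromatic carbon gives an at least 22-fold lower number from compound 2 to compound 4 (1.34 log units; beyond the scatter) on the core of compound 2, so the effect now appears at a much smaller amount of compound. The same change on the core of compound 1 cannot be read, and it offers no size to compare, because both compounds there sit at a limit: (the limit of > 300 uM in this assay, at which 3 of the 4 values shown sit). Among these compounds, the single readable step therefore shows that chloro can matter strongly on one core, but not that this carries over to another core.

Going by these compounds, it remains open whether bromo or methyl on the same aromatic carbon would act like chloro. On these data alone, it is also open whether a longer chain in place of the side chain of compound 3 would give a readable value.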